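A few compounds are considered here, and "the series" means these few. Any claim that something is new, unique, unknown or untested is made for them only; others in the source may bear on it.

Measured in a functional assay with Alpha-1A adrenergic receptor (Homo sapiens) as the target, read by calcium flux; on this read-out higher numbers stand for larger maximal responses and lower numbers for smaller maximal responses:
compound 1 `Cc1cccc(-c2ccccc2OCC2=NCCN2)n1`: 80%
compound 2 `c1cnc(-c2ccccc2OCC2=NCCN2)nc1`: 90%
compound 3 `c1ccc(-c2cnccn2)c(OCC2=NCCN2)c1`: 97%

Of these three numbers, compound 3 carries the highest. Compound 2 comes nearest, a difference that stays within the scatter; compound 1 lies furthest away, a gap beyond the scatter. Compound 4 `c1c[nH]c(-c2ccccc2OCC2=NCCN2)c1` differs from compound 3 in one place: 1H-pyrrol-2-yl in place of pyrazin-2-yl on an aromatic carbon. Among the compounds with values here, the only measured step, a number 7 percentage points higher from compound 2 to compound 3 (within the scatter), concerns the exchange of pyrimidin-2-yl for pyrazin-2-yl and does not speak to a five-membered ring such as 1H-pyrrol-2-yl. Since all three measured values fall in a narrow band, compound 4 is expected to land near them as well, with a step of a number 12 percentage points lower from compound 3 to compound 4 (beyond the scatter) that is not expected to exceed the scatter. Compound 4 is estimated at 85%, with a range from 60% to 105%.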

Compound 4, largest response reached (reported as maximum), in percent of the reference or control that the assay uses: 99%
Compound 4: middle estimate off by 14 percentage points, on the low side, and the stated range covers the measured number.
By their numbers in this assay, from the lowest: compounds 1, 2, 3 and 4 (each within the scatter of the next, the first and the last beyond it).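

In this assay, this place on the aromatic carbon accepts a five-membered ring as well as the six-membered rings of compounds 2 and 3: with 1H-pyrrol-2-yl, the step is a number 2 percentage points higher from compound 3 to compound 4 (within the scatter) and a number 9 percentage points higher from compound 2 to compound 4 (within the scatter). Trading the hydrogen-bond acceptors of pyrazin-2-yl for the single hydrogen-bond donor of 1H-pyrrol-2-yl thus leaves the maximal response within the scatter. No measurement at hand explains this result. Still open, as far as these compounds go, is how the response changes when a group without an aromatic ring, such as an amine, a carboxylic acid or a longer alkyl chain, stands at this place.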